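Swapping the pyridine ether for a trifluoromethylphenyl ether

The compounds below may be only part of what the source reports. "The series", "measured", "known", "first", "only" and "open" are said of these compounds alone.

Measured compounds and their numbers in an ADME assay on PBMC cells (Homo sapiens) for cytotoxicity; a higher number here means that more compound is tolerated, a lower number that less compound is tolerated:
compound 1 `Cc1ccnc(OC(c2ccc(C(F)(F)F)cc2)C2CCN(C(C)CCNC(=O)c3c(Cl)cncc3Cl)CC2)c1`: 33600 nM
compound 2 `COC(=O)c1cccc(OC(c2ccc(C(F)(F)F)cc2)C2CCN(C(C)CCNC(=O)c3c(Cl)cncc3Cl)CC2)n1`: 14600 nM
compound 3 `Cc1cccc(OC(c2ccc(C(F)(F)F)cc2)C2CCN(C(C)CCNC(=O)c3c(Cl)cncc3Cl)CC2)n1`: 6700 nM

Among these three, compound 3 shows the lowest number in this assay, so it is the compound of which the cells tolerate the least. Its nearest neighbour is compound 2, seen in the step of a 2.2-fold lower number from compound 2 to compound 3 (0.34 log units; beyond the scatter), and the widest gap is to compound 1, seen in a 5.0-fold lower number from compound 1 to compound 3 (0.70 log units; beyond the scatter).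

Compound 4 `CC(CCNC(=O)c1c(Cl)cncc1Cl)N1CCC(C(Oc2ccccc2C(F)(F)F)c2ccc(C(F)(F)F)cc2)CC1` has not yet been measured. It differs from compound 3 in one place: 2-(trifluoromethyl)phenyl in place of 6-methylpyridin-2-yl on an oxygen on a saturated carbon. The three measured steps all change the ring that hangs on this same oxygen, and each of them moved the number only modestly: a 2.3-fold lower number from compound 1 to compound 2 (0.36 log units; beyond the scatter), a 5.0-fold lower number from compound 1 to compound 3 (0.70 log units; beyond the scatter) and a 2.2-fold lower number from compound 2 to compound 3 (0.34 log units; beyond the scatter). None of them removes the ring nitrogen, so the direction for compound 4 is not fixed by the data; only the size of earlier changes at this position is known.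

Taking that as a guide, compound 4 is expected to land near compound 3, with an estimated step of a 1.3-fold higher number from compound 3 to compound 4 (0.10 log units; within the scatter) that may fall within the scatter. The estimate for compound 4 is 8500 nM, in a range from 3500 nM to 22000 nM.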

Compound 4, half-maximal cytotoxic concentration: 12500 nM
Compound 4: middle estimate off by 1.5-fold (0.17 log units), on the low side; the measured number falls inside the stated range.
By their numbers in this assay, from the lowest: compounds 3, 4 and 2 (each within the scatter of the next, the first and the last beyond it); then compound 1.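

Within the data shown here, compound 4 is the first compound here whose ring on this oxygen is carbon only, with no ring nitrogen, and in this assay that change leaves the number within the scatter of its neighbours: a 1.9-fold higher number from compound 3 to compound 4 (0.27 log units; within the scatter), and a 1.2-fold lower number from compound 2 to compound 4 (0.07 log units; within the scatter). So, among these compounds, a ring nitrogen is not required for a number in this range, and a 2-(trifluoromethyl)phenyl group can sit on this oxygen in place of either substituted pyridine without a readable shift. Compound 1 remains apart, as seen in a 2.7-fold lower number from compound 1 to compound 4 (0.43 log units; beyond the scatter), but nothing measured here gives a reason for that gap or for any other number in this set.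

Compound 4 loses the ring nitrogen and gains the trifluoromethyl group in a single change, so the compounds shown cannot separate what each contributes, and a plain phenyl or a 2-methylphenyl ring would be needed to do so. As far as these compounds go, it also remains open how a ring on this oxygen carrying an amine or a carboxylic acid would read in this assay.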